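This account rests on a few compounds, and the source may have more. Where it says the series, first, only, none or still open, it means among the compounds named here.

Three compounds built on one shared core were examined in an ADME assay on MT2 cells (Homo sapiens) for cytotoxicity, read by XTT assay, with a stated time of 4 days; on this read-out lower numbers stand for higher toxicity in this test and higher numbers for lower toxicity in this test. Compound 1 `Cc1nc2c(c(-c3cc(F)c4c(c3C)CCCO4)c1[C@H](OC(C)(C)C)C(=O)O)CN(CCCc1cccc(F)c1)CC2` gives only a limit of the assay, > 40000 nM. Compound 2 `Cc1ccc(CCCN2CCc3nc(C)c([C@H](OC(C)(C)C)C(=O)O)c(-c4cc(F)c5c(c4C)CCCO5)c3C2)cc1F` likewise gives a limit, > 40000 nM. Compound 3 `Cc1cccc(CCCN2CCc3nc(C)c([C@H](OC(C)(C)C)C(=O)O)c(-c4cc(F)c5c(c4C)CCCO5)c3C2)c1` also gives a limit, > 40000 nM. Compound 2 and compound 3 differ by 3-methylphenyl in place of 3-fluoro-4-methylphenyl on a saturated chain carbon, three bonds along the chain from an amine nitrogen in a ring. Compound 1 arises from compound 2 by hydrogen in place of methyl on an aromatic carbon; the resulting step that the two limits leave unreadable from compound 2 to compound 1 cannot be sized because every value sits at the same limit (the limit of > 40000 nM in this assay, at which 3 of the 3 values shown sit). Compound 4 `Cc1nc2c(c(-c3cc(F)c4c(c3C)CCCO4)c1[C@H](OC(C)(C)C)C(=O)O)CN(CCCc1ccccc1)CC2` arises from compound 3 by hydrogen in place of methyl on an aromatic carbon, the same kind of change, though here the place is meta to a large group rather than ortho to a fluoro group and para to a large group. In this assay compound 4 is expected to show a step that the limit leaves unreadable from compound 3 to compound 4, an expectation resting on the fact that all three neighbours sit at the limit (the limit of > 40000 nM in this assay, at which 3 of the 3 values shown sit). Compound 4 is therefore estimated at 60000 nM, with a likely range from 40000 nM to 200000 nM.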

Compound 4, half-maximal cytotoxic concentration: > 40000 nM
Compound 4 ended at the assay's limit; the forecaster's own chance of this, stated with the estimate: 90%; the middle value does not contradict the limit.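

No step can be read between compound 4 and compounds 1, 2 and 3, because all four sit at one limit: the limit of > 40000 nM in this assay, at which 4 of the 4 values shown sit. The compounds shown leave open whether swapping hydrogen, methyl or fluoro on the aromatic ring changes toxicity in this test at all.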